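The source may report more compounds than this note shows. Statements on the series, on what has been measured and on what is new or still open speak of the compounds shown alone.

Values in a functional assay on HepG2 cells (Homo sapiens) for antiproliferative activity, read by MTT assay; a higher number here means a weaker inhibitor, a lower number a stronger inhibitor:

- compound 1 `Nc1c(C(=O)N/N=C/c2ccccc2)oc2nc(-c3cccs3)cc(C(F)(F)F)c12` gives 9900 nM
- compound 2 `Nc1c(C(=O)N/N=C/c2ccc(Cl)cc2)oc2nc(-c3cccs3)cc(C(F)(F)F)c12` gives 8100 nM

Compound 2 stands level with compound 1 on these numbers. Putting chloro in place of hydrogen on an aromatic carbon gave a 1.2-fold lower number from compound 1 to compound 2 (0.09 log units; within the scatter), so neither compound can be ranked above the other.

The next compound, compound 3 `CCNC(=O)c1oc2nc(-c3cccs3)cc(C(F)(F)F)c2c1N`, keeps the shared core but replaces much of the side group. The change is a group of 2 heavy atoms (2 carbon; no ring) in place of a group of 9 heavy atoms (7 carbon, 1 nitrogen, 1 chlorine; one six-membered aromatic ring of carbon only), on an amide-type nitrogen. Ethyl enters on an amide-type nitrogen, and the six-membered aromatic ring leaves with the rest of the larger group.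

Among the measured compounds shown here, only one measured step is available as a guide, and it covers far less. The step of a 1.2-fold lower number from compound 1 to compound 2 (0.09 log units; within the scatter) alters a single spot on the ring that compound 3 loses. For the measured compounds named here, no measured compound shows what happens when the whole group goes, so the direction is uncertain. A small move towards a higher number seems the more likely outcome, with wide margins on both sides. The expected step is a 1.9-fold higher number from compound 2 to compound 3 (0.27 log units; within the scatter). For compound 3 the estimated value is 15000 nM, with an expected range of 4000 nM to 50000 nM.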

Compound 3, half-maximal inhibitory concentration: 12100 nM
Compound 3: the middle estimate sits 1.2-fold (0.09 log units) above what was measured, within the range that was stated.
By their numbers in this assay, from the lowest: compounds 2, 1 and 3 (each within the scatter of the next).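

Replacing the whole side group on the amide-type nitrogen with ethyl in this assay gives a 1.5-fold higher number from compound 2 to compound 3 (0.17 log units; within the scatter) and, starting instead from the compound without chloro, a 1.2-fold higher number from compound 1 to compound 3 (0.09 log units; within the scatter). Among the compounds shown here, both steps lie within the scatter, so compound 3 cannot be ranked against either compound, even though it lacks the six-membered aromatic ring and the double bond outside aromatic rings that leave with the larger group; the earlier pair altered only one spot on that ring, whereas these steps show that, in these three compounds, the numbers stay within the scatter when the whole group is gone. Nothing measured here explains this result.

Ethyl is the only small group shown on this nitrogen, so it remains open how a longer chain such as butyl, or a chain ending in an amine or a carboxylic acid, would compare. From the compounds shown here alone, it is also open whether any change at this place can move the number beyond the scatter, as all three compounds sit within the scatter of one another.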